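A Hydroxyl for a Methoxy on the Benzamide Ring

The compounds below may be only part of what the source reports. "The series", "measured", "known", "first", "only" and "open" are said of these compounds alone.

Compound 2 `COc1c(Br)cccc1C(=O)Nc1ccc(Sc2nc3ccccc3s2)cc1` is one of three anilides built on a shared core that were tested in an assay for inhibition of HSP60/HSP10 (Homo sapiens), with a stated time of 60 min; a higher number here means a weaker inhibitor, a lower number a stronger inhibitor. In this assay compound 2 gives > 100000 nM, which is a limit of the assay and not a number. Compound 1 `COc1ccc(Br)cc1C(=O)Nc1ccc(Sc2nc3ccccc3s2)cc1` gives > 100000 nM, also a limit. Compound 3 `COc1c(Br)cc(Br)cc1C(=O)Nc1ccc(Sc2nc3ccccc3s2)cc1` gives > 100000 nM, again a limit. All three results share (the limit of > 100000 nM in this assay, at which 3 of the 3 values shown sit), so the steps among them cannot be read: a step that the two limits leave unreadable from compound 1 to compound 2, a step that the two limits leave unreadable from compound 1 to compound 3 and a step that the two limits leave unreadable from compound 2 to compound 3. Compound 2 therefore stands nowhere in particular among the measured values; it sits at the limit together with the others.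

Compound 4 `O=C(Nc1ccc(Sc2nc3ccccc3s2)cc1)c1cc(Br)ccc1O` has not yet been measured. It differs from compound 2 by a group of 8 heavy atoms (6 carbon, 1 oxygen, 1 bromine; one six-membered aromatic ring of carbon only) in place of a group of 9 heavy atoms (7 carbon, 1 oxygen, 1 bromine; one six-membered aromatic ring of carbon only), on a carbonyl carbon. Among the compounds with values here, none of the measured steps involves a hydroxyl in place of a methoxy, and none of them has a readable size, so the measured data give neither a direction nor a size for this change. The estimated step in this assay is a number no higher from compound 2 to compound 4 (the limit leaves the size open), with a considerable chance that only a limit is reported once more. For compound 4 the expected value in this assay is 100000 nM, within an estimated range from 15000 nM to 500000 nM.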

Compound 4, half-maximal inhibitory concentration: > 100000 nM
Compound 4: no number, only a limit (the forecaster's own chance of this, stated with the estimate: 70%); the middle value lies on the limit itself.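

In this assay compound 4 gives > 100000 nM, which is a limit of the assay and not a number. The steps to compound 4 from compound 1 and compound 2 therefore cannot be read: the limit of > 100000 nM in this assay, at which 4 of the 4 values shown sit.

The compounds shown leave open whether any anilide on this shared core gives a measurable value in this assay, and what size of step hydrogen in place of methyl on the oxygen would produce.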